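Working notes on four related compounds and one open value

The source may hold more compounds than are shown below. What is called first, only, known or untested is meant among the compounds shown, and "the series" means these compounds.

Measured so far:
compound 1 `COc1cccc(/C=C/C(=O)c2ccc(OC)c3c2OC(C)(C)C=C3)c1`: 9360 nM
compound 2 `COc1ccc(C(=O)/C=C/c2cccc(Cl)c2)c2c1C=CC(C)(C)O2`: a limit only, > 10000 nM
compound 3 `COc1ccc(C(=O)/C=C/c2ccccc2Cl)c2c1C=CC(C)(C)O2`: a limit only, > 10000 nM

In a functional assay on SK-OV-3 cells (Homo sapiens) for antiproliferative activity, read by MTT assay, with a stated time of 24 h (on this read-out higher numbers stand for weaker inhibition and lower numbers for stronger inhibition), compound 1 gives 9360 nM. Compound 2 reaches only the limit > 10000 nM. Compound 3 likewise reaches only the limit > 10000 nM, as noted by the limit of > 10000 nM in this assay, at which 2 of the 3 values shown sit. The step of an at least 1.0-fold lower number from compound 2 to compound 1 (0.02 log units; that floor lies within the scatter) carries the change (methoxy in place of chloro on an aromatic carbon). The cores of compound 2 and compound 3 differ by 2-chlorophenyl in place of 3-chlorophenyl on a double-bonded chain carbon bound to a double-bonded chain carbon, and the step that the two limits leave unreadable from compound 2 to compound 3 cannot be sized. The step of an at least 1.0-fold higher number from compound 1 to compound 3 (0.02 log units; that floor lies within the scatter) is also only a floor.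

Compound 4 `COc1ccccc1/C=C/C(=O)c1ccc(OC)c2c1OC(C)(C)C=C2` is not yet measured. Its change from compound 3 is methoxy in place of chloro on an aromatic carbon, the same kind of change as that from compound 2 to compound 1, though there the place was meta to a large group and here it is ortho to a large group. Compound 4 is expected to sit near the limit, with a step of a number no higher from compound 3 to compound 4 (the limit leaves the size open), resting on the unreadable floor of the earlier step. That expectation also rests on compound 3 reaching only the limit > 10000 nM. The estimated value for compound 4 is 10000 nM, from 4000 nM to 30000 nM.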

Compound 4, half-maximal inhibitory concentration: > 10000 nM
Compound 4 ended at the assay's limit; the forecaster's own chance of this, stated with the estimate: 55%; the middle value lies on the limit itself.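

In this assay compound 4 gives > 10000 nM, which is a limit and not a number, so methoxy in place of chloro cannot be sized on this core: the limit of > 10000 nM in this assay, at which 3 of the 4 values shown sit.
The steps from compound 3 to compound 4 and from compound 2 to compound 4 cannot be read, so these data neither confirm nor rule out that the change carries over from one core to the other. Among these compounds, the only readable new step is an at least 1.0-fold higher number from compound 1 to compound 4 (0.02 log units; that floor lies within the scatter), which is just a floor and sets no order between the two compounds.

The compounds shown leave open how an amine or a carboxylic acid in place of chloro or methoxy on the phenyl would read in this assay, and whether either would give a value clear of the limit.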